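Adding isopropoxy to compound 3

The source may report more compounds than this note shows. Statements on the series, on what has been measured and on what is new or still open speak of the compounds shown alone.

Values in an ADME assay on HEp-2 cells (Homo sapiens) for cytotoxicity, read by MTT assay, with a stated time of 72 h; a higher number here means a weaker inhibitor, a lower number a stronger inhibitor:
- Compound 1 `COc1ccc(C2=C(c3cc(OC)c(OC)c(OC)c3)C(=O)C(OC(C)=O)C2)cc1OC(C)C`: > 100 ug/mL, a limit of the assay
- Compound 2 `COc1ccc(C2=C(c3cc(OC)c(OC)c(OC)c3)C(=O)C(OC(C)=O)C2)cc1`: 18 ug/mL
- Compound 3 `COc1ccc(C2=C(c3cc(OC)c(OC)c(OC)c3)C(=O)C(O[SiH2]C(C)(C)C)C2)cc1`: 16 ug/mL

Compound 3 gives 16 ug/mL, level with compound 2 given the step of a 1.1-fold lower number from compound 2 to compound 3 (0.05 log units; within the scatter). Compound 1 reports only a limit. Compound 4 `COc1ccc(C2=C(c3cc(OC)c(OC)c(OC)c3)C(=O)C(O[SiH2]C(C)(C)C)C2)cc1OC(C)C` differs from compound 3 by isopropoxy in place of hydrogen on an aromatic carbon. Going by the values given here, the one measured step that bears on this is the same exchange run the other way, an at least 5.5-fold lower number from compound 1 to compound 2 (0.74 log units; beyond the scatter). A clear rise in this assay is therefore expected, of similar size, and it may reach the limit. The expected step is a 5.3-fold higher number from compound 3 to compound 4 (0.73 log units; beyond the scatter). For compound 4 the estimated value is 85 ug/mL, with an expected range of 35 ug/mL to 200 ug/mL.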

Compound 4, half-maximal inhibitory concentration: 7.1 ug/mL
Compound 4: the middle estimate sits 12-fold (1.08 log units) above what was measured; the measured number lies below the stated range.
By their numbers in this assay, from the lowest: compound 4; then compounds 3 and 2 (each within the scatter of the next). At a limit, above all of these: compound 1.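

In this assay, isopropoxy on this aromatic carbon, ortho to a methoxy group, now lowers the number, a 2.3-fold lower number from compound 3 to compound 4 (0.35 log units; beyond the scatter), so the direction of its effect differs between the two cores: the same change on two cores in this assay, an at least 5.5-fold lower number (0.74 log units; beyond the scatter) from compound 1 to compound 2 and a 2.3-fold higher number (0.35 log units; beyond the scatter) from compound 4 to compound 3, at least 12-fold (1.09 log units) apart, beyond the scatter of two such steps. The exchange on the oxygen on a saturated carbon, which stayed within the scatter from compound 2 to compound 3, becomes a large step once isopropoxy is present, an at least 14-fold lower number from compound 1 to compound 4 (1.14 log units; beyond the scatter): the same change on two cores in this assay, a 1.1-fold lower number (0.05 log units; within the scatter) from compound 2 to compound 3 and an at least 14-fold lower number (1.14 log units; beyond the scatter) from compound 1 to compound 4, at least 12-fold (1.09 log units) apart, beyond the scatter of two such steps. Compound 1 reports a limit, not a number: the limit of > 100 ug/mL in this assay, at which 1 of the 4 values shown sits.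

The compounds shown leave open whether a hydroxyl, an amine or a longer alkoxy chain on this aromatic carbon would follow isopropoxy on either core. They also leave open whether any other group on the saturated carbon's oxygen would show the same dependence.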